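From 4-vinylphenyl to 3-methylphenyl on the Shared Core

The source may report more compounds than this note shows. Statements on the series, on what has been measured and on what is new or still open speak of the compounds shown alone.

In a functional assay on HeLa cells (Homo sapiens) for inhibition, read by CCK-8 assay, with a stated time of 48 h (on this read-out lower numbers stand for stronger inhibition and higher numbers for weaker inhibition), compound 1 `COc1cc(-c2ccnc3cc(-c4ccc(Cl)cc4)nn23)cc(OC)c1OC` gives 1490 nM and compound 2 `C=Cc1ccc(-c2cc3nccc(-c4cc(OC)c(OC)c(OC)c4)n3n2)cc1` gives 882 nM. Among the measured compounds shown here, these are the only two numbers available, and they lie within the scatter of each other, so compound 2 cannot be ranked against compound 1.

Compound 3 `COc1cc(-c2ccnc3cc(-c4cccc(C)c4)nn23)cc(OC)c1OC`, not yet measured, keeps the shared core and carries 3-methylphenyl in place of 4-vinylphenyl on an aromatic carbon.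

For the measured compounds named here, one measured step bears on this change, vinyl in place of chloro on an aromatic carbon, which gave a 1.7-fold lower number from compound 1 to compound 2 (0.23 log units; within the scatter). That step exchanged one substituent for another on the same aromatic ring. Going by the values given here, no measured compound carries a methyl group, and none shows what happens when a group sits at a different place on that ring, so the evidence is thin. Among the compounds with values here, with only this small step as a guide, no change beyond the scatter is expected in this assay. The expected step is a 1.4-fold higher number from compound 2 to compound 3 (0.13 log units; within the scatter). For compound 3 the estimate is 1200 nM, with an expected range of 400 nM to 3500 nM.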

Compound 3, half-maximal inhibitory concentration: 4230 nM
For compound 3 the middle estimate is 3.5-fold (0.55 log units) below the measured one; the whole stated range lies below it.
By their numbers in this assay, from the lowest: compounds 2 and 1 (each within the scatter of the next); then compound 3.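

In this assay, the aryl group on this carbon of the five-membered aromatic ring proved able to move the number beyond the scatter: 3-methylphenyl in place of 4-vinylphenyl gave a 4.8-fold higher number from compound 2 to compound 3 (0.68 log units; beyond the scatter), and 3-methylphenyl in place of 4-chlorophenyl gave a 2.8-fold higher number from compound 1 to compound 3 (0.45 log units; beyond the scatter). The earlier exchange of chloro for vinyl had shown no such separation, so compound 3 is the weakest of the three, while compound 1 and compound 2 remain within the scatter of each other. Nothing shown here explains why the number rose with 3-methylphenyl.

Both new steps change the substituent and its place on the phenyl ring together, so the compounds shown cannot separate the effect of the methyl group from the effect of where it sits. Also open, on these data alone, is how the number would respond to an amine or a carboxylic acid on that phenyl ring, or to a longer chain in place of the methyl group.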